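This account rests on a few compounds, and the source may have more. Where it says the series, first, only, none or still open, it means among the compounds named here.

Measured in a functional assay on HeLa cells (Homo sapiens) for inhibition; a lower number here means a stronger inhibitor, a higher number a weaker inhibitor:
- Compound 1 `O=C(CC(CC(=O)NC1Cc2ccccc2C1)c1ccccc1)NCCN1CCCC1`: > 100000 nM (a limit)
- Compound 2 `CCN(CC)CCNC(=O)CC(CC(=O)NC1Cc2ccccc2C1)c1ccccc1`: > 100000 nM (a limit)

Compound 1 has no exact number, only the limit > 100000 nM. Compound 2 also reaches only a limit, > 100000 nM. Together they give (the limit of > 100000 nM in this assay, at which 2 of the 2 values shown sit).

Compound 3 `CCN(C(=O)CC(CC(=O)NCCN1CCCC1)c1ccccc1)C1Cc2ccccc2C1` differs from compound 1 by ethyl in place of hydrogen on an amide-type nitrogen. Within the data shown here, the only measured step, a step that the two limits leave unreadable from compound 1 to compound 2, is a different change, and its size cannot be read. Going by these compounds, it therefore offers no measured size to carry over, and the direction stays open. Since compound 1 sits at > 100000 nM, the likeliest result in this assay is another limit, with no clear step expected. The expected change is a number no higher from compound 1 to compound 3 (the limit leaves the size open). For compound 3 the estimated value is 100000 nM, with an expected range from 20000 nM to 300000 nM.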

Compound 3, half-maximal inhibitory concentration: > 100000 nM
Compound 3 ended at the assay's limit; the forecaster's own chance of this, stated with the estimate: 65%; the middle value lies on the limit itself.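

Compound 3, like compound 1, reaches only a limit, and the step with ethyl in place of hydrogen on the amide-type nitrogen therefore cannot be read: the limit of > 100000 nM in this assay, at which 3 of the 3 values shown sit.

The compounds shown leave open whether any change to the shared core gives an exact value in this assay at all.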